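Swapping the carbamate for a nitrophenyl group on the piperazine

The source may hold more compounds than are shown below. What is called first, only, known or untested is meant among the compounds shown, and "the series" means these compounds.

Compound 2 `CCCCCCCCn1cc(/C=C/C(=O)c2ccc(NC(=O)CN3CCN(C(=O)OC(C)(C)C)CC3)cc2)nn1` gives 43300 nM in a functional assay on A549 cells (Homo sapiens) for inhibition, read by MTT assay; a lower number here means a stronger inhibitor, a higher number a weaker inhibitor. Among the compounds with values here, its only measured neighbour is compound 1 `CCCCCCCCn1cc(/C=C/C(=O)c2ccc(NC(=O)CN3CCN(c4ccccc4F)CC3)cc2)nn1`, which in this assay gives 47100 nM; the step of a 1.1-fold lower number from compound 1 to compound 2 (0.04 log units; within the scatter) puts the two side by side within the scatter. Compound 3 `CCCCCCCCn1cc(/C=C/C(=O)c2ccc(NC(=O)CN3CCN(c4ccc([N+](=O)[O-])cc4)CC3)cc2)nn1` differs from compound 2 by 4-nitrophenyl in place of tert-butoxycarbonyl on an amine nitrogen in a ring. Within the data shown here, the single step that bears on this change, from compound 1 to compound 2, exchanged an aryl group for the same carbamate without moving the number, so no step beyond the scatter is expected for compound 3, giving an estimated 1.0-fold higher number from compound 2 to compound 3 (0.02 log units; within the scatter). Compound 3 is therefore expected at 45000 nM, in the range 20000 nM to 100000 nM.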

Compound 3, half-maximal inhibitory concentration: 45400 nM
Beside the measured number, compound 3's estimate is 1.0-fold (0.00 log units) below it, and the stated range covers the measured number.
By their numbers in this assay, from the lowest: compounds 2, 3 and 1 (each within the scatter of the next).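

With 4-nitrophenyl on the amine nitrogen in the ring, this assay reads the same within the scatter as with tert-butoxycarbonyl (a 1.0-fold higher number from compound 2 to compound 3 (0.02 log units; within the scatter)) and as with 2-fluorophenyl (a 1.0-fold lower number from compound 1 to compound 3 (0.02 log units; within the scatter)). A second substituted phenyl group at this position, with its substituent at a different place on the ring, thus joins the first and the carbamate in one narrow band. No measurement given here accounts for this. The compounds shown leave open whether a free amine or a carboxylic acid at this position would separate from that band. They also leave open whether changes elsewhere on the shared core would do so.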